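Swapping an Isobutyl for a Methoxyphenyl on a Shared Core

The source may report more compounds than this note shows. Statements on the series, on what has been measured and on what is new or still open speak of the compounds shown alone.

Three compounds share one core and differ only in the group on a saturated chain carbon bound to an aromatic nitrogen. In an assay on isolated protein for inhibition of aldehyde dehydrogenase 1A1 (Homo sapiens), read by spectrophotometry, tested at 10 uM (a higher number here means more inhibition at the concentration tested (going by the name of the read-out), a lower number less inhibition), compound 1 `CC(C)=CCn1c(CN2CCN(C(=O)C3CC3)CC2)nc2ccccc21` gives 74.3%. Compound 3 `CC(C)CCn1c(CN2CCN(C(=O)C3CC3)CC2)nc2ccccc21` gives 70%, the second highest of the three numbers. The step of a number 4.3 percentage points lower from compound 1 to compound 3 (within the scatter) lies within the scatter, whereas compound 2 `O=C(C1CC1)N1CCN(Cc2nc3ccccc3n2Cc2ccccc2)CC1` gives only 23.9%. Compound 4 `COc1cccc(Cn2c(CN3CCN(C(=O)C4CC4)CC3)nc3ccccc32)c1` has not yet been measured; it differs from compound 3 by 3-methoxyphenyl in place of isobutyl on a saturated chain carbon bound to an aromatic nitrogen. Two earlier steps bear on this change: a number 50.4 percentage points lower from compound 1 to compound 2 (beyond the scatter) and a number 46.1 percentage points higher from compound 2 to compound 3 (beyond the scatter), both large, each showing lower inhibition when a phenyl stands there than when an alkyl chain does. The change to compound 4 is therefore expected to bring a large drop, a number 42 percentage points lower from compound 3 to compound 4 (beyond the scatter). Compound 4 is estimated at 28%, within 8% to 55%.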

Compound 4, a percentage reported as inhibition, at one concentration (the size of the read-out at that concentration, not a potency): 44.4%
Beside the measured number, compound 4's estimate is 16.4 percentage points below it, within the range that was stated.
By their numbers in this assay, from the lowest: compound 2; then compound 4; then compounds 3 and 1 (each within the scatter of the next).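

In this assay, an aromatic ring at this position still costs inhibition against either alkyl chain, with a number 25.6 percentage points lower from compound 3 to compound 4 (beyond the scatter) and a number 29.9 percentage points lower from compound 1 to compound 4 (beyond the scatter) as the two steps. What is new is that substitution on the ring itself matters: methoxy in place of hydrogen gives a number 20.5 percentage points higher from compound 2 to compound 4 (beyond the scatter) and recovers part of the loss seen with phenyl. No measurement available here explains this recovery. Still open, going by these compounds, is how a chain longer than isopentyl would behave, or a benzyl group carrying an amine or a carboxylic acid instead of methoxy.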